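Chloro in Place of Methoxy and an Expected Value

The source may hold more compounds than are shown below. What is called first, only, known or untested is meant among the compounds shown, and "the series" means these compounds.

Compound 1 `COc1cc(-c2nnc3n2NC(c2ccco2)C(C(=O)c2ccc(Cl)cc2)S3)cc(OC)c1OC`: in a functional assay on A549 cells (Homo sapiens) for cytotoxicity, read by MTT assay, with a stated time of 48 h (on this read-out lower numbers stand for stronger inhibition and higher numbers for weaker inhibition), compound 1 gives 51400 nM.
Compound 2 `COc1ccc(C(=O)C2Sc3nnc(-c4cc(OC)c(OC)c(OC)c4)n3NC2c2cccs2)cc1`: in this assay compound 2 reaches only a limit of the assay, > 100000 nM, not a number.
Compound 3 `COc1ccc(C(=O)C2Sc3nnc(-c4cc(OC)c(OC)c(OC)c4)n3NC2c2ccco2)cc1`: in this assay compound 3 also reaches only a limit, > 100000 nM.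

Compounds 3 and 1 differ in one place: chloro in place of methoxy on an aromatic carbon. This change gives an at least 1.9-fold lower number from compound 3 to compound 1 (0.28 log units; that floor lies within the scatter). Compounds 3 and 2 differ in their cores: thiophen-2-yl in place of furan-2-yl on a saturated ring carbon. The step that the two limits leave unreadable from compound 2 to compound 3 stays unreadable because the limit of > 100000 nM in this assay, at which 2 of the 3 values shown sit, covers both values.

Compound 4 `COc1cc(-c2nnc3n2NC(c2cccs2)C(C(=O)c2ccc(Cl)cc2)S3)cc(OC)c1OC` has not been measured. It differs from compound 2 by chloro in place of methoxy on an aromatic carbon, the same change, at the same place, as from compound 3 to compound 1. The expected step is an at least 1.4-fold lower number from compound 2 to compound 4 (0.15 log units; that floor lies within the scatter), and it rests on the measured at least 1.9-fold lower number from compound 3 to compound 1 (0.28 log units; that floor lies within the scatter). Compound 4 is estimated at 70000 nM. Its expected range runs from 30000 nM to 160000 nM. Since compound 2 sits at a limit, the result for compound 4 may again be only a limit rather than a number.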

Compound 4, half-maximal inhibitory concentration: 20100 nM
Estimate against measurement, compound 4: 3.5-fold (0.54 log units) above, outside the stated range (below it).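

In this assay the change from 4-methoxyphenyl to 4-chlorophenyl gives an at least 4.9-fold lower number from compound 2 to compound 4 (0.69 log units; beyond the scatter), so on the core carrying thiophen-2-yl the chloro compound is clearly the stronger of the pair. Set beside the same change on the core carrying furan-2-yl, the direction agrees, but only the step on the thiophen-2-yl core is shown to lie beyond the scatter, and no difference in size between the two cores can be claimed: the same change on two cores in this assay, an at least 1.9-fold lower number (0.28 log units; that floor lies within the scatter) from compound 3 to compound 1 and an at least 4.9-fold lower number (0.69 log units; beyond the scatter) from compound 2 to compound 4; the limit leaves it open whether they differ. With the 4-chlorophenyl group held fixed, thiophen-2-yl in place of furan-2-yl gives a 2.6-fold lower number from compound 1 to compound 4 (0.41 log units; beyond the scatter), while the matching step between the two methoxy compounds cannot be read: the limit of > 100000 nM in this assay, at which 2 of the 4 values shown sit.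

Going by these compounds, whether an amine or a carboxylic acid at the same place on the six-membered aromatic ring would also lower the number stays open. So does whether the change carries over to a core with a longer chain in place of furan-2-yl or thiophen-2-yl.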